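The compounds below may be only part of what the source reports. "The series", "measured", "known", "first", "only" and "open" are said of these compounds alone.

Compound 1 `COC(=O)c1c(Nc2ccccc2)sc(C(=O)c2ccc(OC)cc2)c1C` and compound 2 `COC(=O)c1c(Nc2ccccc2)sc(C(=O)c2ccc(C)cc2)c1C` share a core and differ only in the group on the benzoyl ring. In a functional assay, with a stated time of 150 min, tested at 35 ug/mL (on this read-out higher numbers stand for a stronger effect at the one concentration tested and lower numbers for a weaker effect), compound 1 gives 63%, whereas compound 2 gives 10.3%. The change methoxy in place of methyl on an aromatic carbon therefore made a step of a number 52.7 percentage points higher from compound 2 to compound 1 (beyond the scatter) in this assay.

Compound 3 `COc1ccc(C(=O)c2sc(Nc3ccc(C)cc3)c(C(=O)O)c2C)cc1` is built on a different core; how the two cores differ is not broken down here. In this assay compound 3 is reported as "not active" (no number reported). Compound 4 `COc1ccc(Nc2sc(C(=O)c3ccc(OC)cc3)c(C)c2C(=O)O)cc1` arises from compound 3 by the change (methoxy in place of methyl on an aromatic carbon), which, cut one bond further out, reads (4-methylphenyl)amino to (4-methoxyphenyl)amino, the same kind of change that was made from compound 2 to compound 1, though on a different part of the molecule.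

Among the compounds with values here, because compound 3 is reported as "not active" (no number reported), and because a number 52.7 percentage points higher from compound 2 to compound 1 (beyond the scatter), the only measured precedent for the change, sits on another ring of another core, only a modest response is expected for compound 4. Compound 4 is estimated to give 15% in this assay, with a likely range from 0% to 45%.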

Compound 4, a percentage reported as activity, at one concentration (the size of the read-out at that concentration, not a potency): 51%
For compound 4 the middle estimate is 36 percentage points below the measured one, and the stated range ends below it.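

In this assay compound 3 is reported as "not active" (no number reported) and compound 4 gives 51%, so no step can be read between these two compounds. The compounds shown leave open how large the effect of going from (4-methylphenyl)amino to (4-methoxyphenyl)amino is on this core. Nothing shown here bears on the cause of this result.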